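Swapping the piperidine tail back in from an open chain

This account rests on a few compounds, and the source may have more. Where it says the series, first, only, none or still open, it means among the compounds named here.

Measured compounds:
compound 1 `COc1cc(C)c(S(=O)(=O)N(C)CCOCC(=O)N2CCN(C3CCN(C4CC4)CC3)CC2)c(C)c1` gives 0.8 nM
compound 2 `COc1cc(C)c(S(=O)(=O)N(C)CCOCC(=O)N2CCN(CC3CCN(C)CC3)CC2)c(C)c1` gives 4.5 nM
compound 3 `COc1cc(C)c(S(=O)(=O)N(C)CCOCC(=O)N2CCN(CCCN(C)C)CC2)c(C)c1` gives 5.8 nM

All three were tested in an assay on HEK293 cells for displacement of a labelled ligand from B1 bradykinin receptor (Homo sapiens), read by scintillation counting (a lower number here means a stronger inhibitor, a higher number a weaker inhibitor), and differ only in the group on an amine nitrogen of the shared core. Compound 3 stands at the highest number of the three, though compound 2 sits within the scatter of it, as a 1.3-fold higher number from compound 2 to compound 3 (0.11 log units; within the scatter) shows. Compound 4 `CCN1CCC(N2CCN(C(=O)COCCN(C)S(=O)(=O)c3c(C)cc(OC)cc3C)CC2)CC1` has not yet been measured. The change is 1-ethylpiperidin-4-yl in place of 3-(dimethylamino)propyl on an amine nitrogen in a ring. Among the measured compounds shown here, two measured steps bear on it. Compound 1 carries a 1-cyclopropylpiperidin-4-yl group on the same nitrogen, and going from it to compound 3 gave a 7.3-fold higher number from compound 1 to compound 3 (0.86 log units; beyond the scatter), while going to compound 2 gave a 5.6-fold higher number from compound 1 to compound 2 (0.75 log units; beyond the scatter). Compound 4 brings back a piperidin-4-yl group on that nitrogen, close to compound 1, so a step of a 4.8-fold lower number from compound 3 to compound 4 (0.68 log units; beyond the scatter) is expected, largely reversing the loss seen from compound 1 to compound 3. Compound 4 is therefore estimated at 1.2 nM, within a range of 0.5 nM to 3 nM.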

Compound 4, inhibition constant: 0.2 nM
Compound 4: the middle estimate sits 6.0-fold (0.78 log units) above what was measured; the whole stated range lies above it.
By their numbers in this assay, from the lowest: compound 4; then compound 1; then compounds 2 and 3 (each within the scatter of the next).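

In this assay, 1-ethylpiperidin-4-yl on this amine nitrogen outperforms both the open chain and the (1-methylpiperidin-4-yl)methyl group by a large margin, with a 29-fold lower number from compound 3 to compound 4 (1.46 log units; beyond the scatter) and a 23-fold lower number from compound 2 to compound 4 (1.35 log units; beyond the scatter). The earlier compounds shown here also could not show that the small group on the amine nitrogen of the piperidin-4-yl ring matters, yet ethyl in place of cyclopropyl gives a 4.0-fold lower number from compound 1 to compound 4 (0.60 log units; beyond the scatter), so compound 4 holds the lowest number of the four. Nothing shown here explains why these changes have these effects.

Still open, as far as these compounds go, is how other small groups on that nitrogen, such as methyl or isopropyl, would compare with ethyl and cyclopropyl. The compounds shown also leave open what a plain hydrogen on that nitrogen would give.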